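From chloromethyl to fluorophenyl on the ester carbonyl

The source may report more compounds than this note shows. Statements on the series, on what has been measured and on what is new or still open speak of the compounds shown alone.

Compound 1 `C=C1C(=O)O[C@@H]2CC(C)=C([C@@H](C)CCCOC(C)=O)[C@@H](OC(=O)CCl)[C@H]12`: 26500 nM in a functional assay on SGC-7901 cells (Homo sapiens) for cytotoxicity, read by sulforhodamine B assay, with a stated time of 72 h; on this read-out lower numbers stand for stronger inhibition and higher numbers for weaker inhibition
Compound 2 `C=C1C(=O)O[C@@H]2CC(C)=C([C@@H](C)CCCOC(C)=O)[C@@H](OC(=O)c3cccc(F)c3)[C@H]12`: 12900 nM

Among the two measured compounds, compound 1 gives the highest number in this assay; compound 2 is its only neighbour. Among the compounds with values here, the single measured step, a 2.1-fold lower number from compound 1 to compound 2 (0.31 log units; beyond the scatter), came with 3-fluorophenyl in place of chloromethyl on a carbonyl carbon.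

Compound 3 `C=C1C(=O)O[C@@H]2CC(C)=C([C@@H](C)CCCOC(C)=O)[C@@H](OC(=O)c3ccc(F)cc3)[C@H]12` has not yet been measured. It differs from compound 1 by 4-fluorophenyl in place of chloromethyl on a carbonyl carbon. This closely mirrors the change behind a 2.1-fold lower number from compound 1 to compound 2 (0.31 log units; beyond the scatter), so a modest downward step of similar size is expected, a 2.0-fold lower number from compound 1 to compound 3 (0.31 log units; beyond the scatter). Compound 3 is therefore estimated at 13000 nM, expected to fall between 6000 nM and 30000 nM.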

Compound 3, half-maximal inhibitory concentration: 13600 nM
The estimate for compound 3 lay 1.0-fold (0.02 log units) below the measured number, within the range that was stated.
By their numbers in this assay, from the lowest: compounds 2, 3 and 1 (each within the scatter of the next, the first and the last beyond it).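

The step of a 1.1-fold higher number from compound 2 to compound 3 (0.02 log units; within the scatter) came with 4-fluorophenyl in place of 3-fluorophenyl, so moving the fluorine on this ring gives no change that can be told from the scatter. The step of a 1.9-fold lower number from compound 1 to compound 3 (0.29 log units; within the scatter) came with 4-fluorophenyl in place of chloromethyl, so in this assay only compound 2 stands clearly apart from compound 1. No measurement shown here explains these numbers.

Still open, on these data alone, is how a plain phenyl, a 4-methoxyphenyl or an aminomethyl group would read on this carbonyl carbon. As far as these compounds go, a longer chain in place of chloromethyl is equally open.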